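Shrinking the Group on the Sulfonyl Sulfur

This account rests on a few compounds, and the source may have more. Where it says the series, first, only, none or still open, it means among the compounds named here.

Measured so far:
compound 1 `CC(C)OC(=O)NCCS(=O)(=O)NC(=O)c1ccc(Nc2nc(NC3(c4ccc(Cl)cc4)CC3)nc(OCC(F)(F)F)n2)cc1`: 73%
compound 2 `CCS(=O)(=O)NC(=O)c1ccc(Nc2nc(NC3(c4ccc(Cl)cc4)CC3)nc(OCC(F)(F)F)n2)cc1`: 85%
compound 3 `O=C(NS(=O)(=O)c1ccc(F)cc1)c1ccc(Nc2nc(NC3(c4ccc(Cl)cc4)CC3)nc(OCC(F)(F)F)n2)cc1`: 99%

All three compounds share one core and differ only in the group attached to the sulfonyl sulfur. In an ADME assay on microsomes from liver (Rattus norvegicus) for metabolic stability, with a stated time of 10 min (on this read-out higher numbers stand for a more stable compound and lower numbers for a less stable compound), compound 1 gives 73% and stands lowest of the three. Compound 2 gives 85%, and the step of a number 12 percentage points higher from compound 1 to compound 2 (beyond the scatter) carries the compound clearly beyond the scatter. Compound 3 gives 99%; the step of a number 26 percentage points higher from compound 1 to compound 3 (beyond the scatter) is the largest seen here, and a number 14 percentage points higher from compound 2 to compound 3 (beyond the scatter) shows that compound 3 also lies above compound 2.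

Compound 4 `CN(C)S(=O)(=O)NC(=O)c1ccc(Nc2nc(NC3(c4ccc(Cl)cc4)CC3)nc(OCC(F)(F)F)n2)cc1` has not yet been measured. Its difference from compound 1 is dimethylamino in place of 2-((isopropoxycarbonyl)amino)ethyl on a sulfonyl sulfur. The two measured steps that leave compound 1 both replace the 2-((isopropoxycarbonyl)amino)ethyl group with something smaller and both raise the percent remaining. The dimethylamino group of compound 4 is, like the ethyl group of compound 2, a small substituent without the carbamate chain, so a step of the size of a number 12 percentage points higher from compound 1 to compound 2 (beyond the scatter) is the closest guide. Compound 4 is therefore expected to be more stable than compound 1 by about a number 11 percentage points higher from compound 1 to compound 4 (beyond the scatter). For compound 4 the estimate is 84%, with a likely range from 72% to 95%.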

Compound 4, percent of the compound remaining: 76%
Compound 4: middle estimate off by 8 percentage points, on the high side; the range from low to high includes it.
By their numbers in this assay, from the lowest: compounds 1, 4 and 2 (each within the scatter of the next, the first and the last beyond it); then compound 3.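

In this assay, the step to dimethylamino on the sulfonyl sulfur reads a number 3 percentage points higher from compound 1 to compound 4 (within the scatter), so replacing the 2-((isopropoxycarbonyl)amino)ethyl group with one of 3 heavy atoms instead of 9 does not by itself separate the two compounds. Set against the ethyl group, the same substituent gives a number 9 percentage points lower from compound 2 to compound 4 (within the scatter), so dimethylamino cannot be told apart from ethyl either, even though the step from the carbamate chain to ethyl alone lies beyond the scatter, and a small group on this sulfur therefore does not guarantee a clear gain. Only the 4-fluorophenyl group stands clear of dimethylamino, with a number 23 percentage points lower from compound 3 to compound 4 (beyond the scatter), which leaves compound 3 above the other three; no measurement at hand explains why these groups differ.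

The compounds shown leave open whether the high value of compound 3 goes with the aromatic ring itself or with its fluorine, a question that a plain phenyl group on the sulfonyl sulfur would address. They also leave open where a cyclic amine such as morpholine would fall relative to dimethylamino.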